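This account rests on a few compounds, and the source may have more. Where it says the series, first, only, none or still open, it means among the compounds named here.

In an ADME assay (liver) for metabolic stability, with Liver microsome (Homo sapiens) as the target, using microsomes (a higher number here means faster removal of the compound, a lower number slower removal), compound 1 (`Fc1ccccc1CNc1nnc(-c2c[nH]c3ncccc23)o1`) gives 32 mL.min-1.g-1, compound 2 (`Fc1cccc(CNc2nnc(-c3c[nH]c4ncccc34)o2)c1`) gives 54 mL.min-1.g-1 and compound 3 (`Fc1ccc(CNc2nnc(-c3c[nH]c4ncccc34)o2)cc1`) gives 47 mL.min-1.g-1. These three differ only in which fluorophenyl group they carry, and compound 3 cannot be told apart from the other two: the measured steps are a 1.5-fold higher number from compound 1 to compound 3 (0.17 log units; within the scatter) and a 1.1-fold lower number from compound 2 to compound 3 (0.06 log units; within the scatter), while a 1.7-fold higher number from compound 1 to compound 2 (0.23 log units; within the scatter) also stays small. Compound 4 (`c1ccc(CNc2nnc(-c3c[nH]c4ncccc34)o2)nc1`) differs from compound 3 in a new way: pyridin-2-yl in place of 4-fluorophenyl on a saturated chain carbon bound to a nitrogen on an aromatic ring. Among the measured compounds shown here, no measured step tests this swap of the ring itself, so those steps offer only weak guidance. Starting from compound 3 at 47 mL.min-1.g-1, a modest move to a lower number is expected. The expected change is a 1.7-fold lower number from compound 3 to compound 4 (0.22 log units; within the scatter). The estimate for compound 4 is 28 mL.min-1.g-1, within an expected range of 12 mL.min-1.g-1 to 55 mL.min-1.g-1.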

Compound 4, intrinsic clearance in microsomes: < 14 mL.min-1.g-1
Compound 4 ended at the assay's limit (the forecaster's own chance of this, stated with the estimate: 8%); at least 2.0-fold (0.30 log units) between middle value and limit.
By their numbers in this assay, from the lowest: compounds 1, 3 and 2 (each within the scatter of the next). At a limit, below all of these: compound 4.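

Swapping one fluorophenyl group for another at this position, on a saturated chain carbon bound to a nitrogen on an aromatic ring, stayed within the scatter, but changing the ring itself does not: an at least 3.3-fold lower number from compound 3 to compound 4 (0.52 log units; beyond the scatter), an at least 3.8-fold lower number from compound 2 to compound 4 (0.58 log units; beyond the scatter) and an at least 2.2-fold lower number from compound 1 to compound 4 (0.35 log units; beyond the scatter). Compound 4 has no fluorine and gains a ring nitrogen, which counts as a hydrogen-bond acceptor. Its value is a limit of the assay, not a number: the limit of < 14 mL.min-1.g-1 in this assay, at which 1 of the 4 values shown sits.

The compounds shown leave open whether the ring nitrogen or the missing fluorine matters, which plain phenyl would help separate. Pyridin-3-yl and pyridin-4-yl also remain open, as does the true size of the step.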